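Adding a Chloro to Compound 2: Expected Antagonist Potency

This account rests on a few compounds, and the source may have more. Where it says the series, first, only, none or still open, it means among the compounds named here.

Compound 1 `Cc1nc(NC(C2CC2)C2CC2)c2nc(C)n(-c3ccc(S(C)(=O)=O)cc3)c2n1`: 140 nM
Compound 2 `Cc1nc(NC(C2CC2)C2CC2)c2nc(C)n(-c3ccc(OC(F)F)cc3)c2n1`: 5 nM

For the measured compounds named here, in a functional assay on CHO cells for antagonist activity at corticotropin-releasing factor receptor 1 (Homo sapiens), read by cAMP accumulation (on this read-out lower numbers stand for stronger inhibition and higher numbers for weaker inhibition), compound 2 gives 5 nM, the lowest of the two numbers, and its only neighbour is compound 1 with 140 nM; that step, a 28-fold lower number from compound 1 to compound 2 (1.45 log units; beyond the scatter), is the one measured step.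

Compound 3 `Cc1nc(NC(C2CC2)C2CC2)c2nc(C)n(-c3ccc(OC(F)F)cc3Cl)c2n1` differs from compound 2 by chloro in place of hydrogen on an aromatic carbon. Going by the values given here, the single measured step concerns a different group at a different place and so does not bear directly on this change. Only a small shift, likely within the scatter, is expected in this assay, giving a 1.3-fold lower number from compound 2 to compound 3 (0.10 log units; within the scatter).

The estimate for compound 3 is therefore 4 nM, between 1.2 nM and 14 nM.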

Compound 3, inhibition constant: 0.373 nM
The estimate for compound 3 lay 11-fold (1.03 log units) above the measured number; the measured number lies below the stated range.
By their numbers in this assay, from the lowest: compound 3; then compound 2; then compound 1.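

On the aromatic ring, chloro in place of hydrogen, ortho to a large group and meta to the difluoromethoxy group, gives a 13-fold lower number from compound 2 to compound 3 (1.13 log units; beyond the scatter) in this assay. This place carries hydrogen in both earlier compounds, and the new step shows that one added heavy atom here can move the number well beyond the scatter. Nothing measured here explains why a single chlorine has so large an effect.

The compounds shown leave open whether fluoro, methyl or methoxy at this place would do the same. They also leave open whether chloro would give a similar step alongside the methylsulfonyl group of compound 1.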